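The source may hold more compounds than are shown below. What is called first, only, known or untested is meant among the compounds shown, and "the series" means these compounds.

Of the compounds shown here, two that share a core have been read so far in an in vitro ADME assay on microsomes from liver (Homo sapiens) for metabolic stability; on this read-out higher numbers stand for fast clearance and lower numbers for slow clearance. Compound 1 (`CCOCc1cccc2c1CCC2c1ncc[nH]1`) gives 115 mL.min-1.g-1, and compound 2 (`COCCc1cccc2c1CCC2c1ncc[nH]1`) gives 38 mL.min-1.g-1, the lower of the two numbers. Compound 3 (`Fc1ccn(Cc2cccc3c2CCC3c2ncc[nH]2)n1`) has not yet been measured. It differs from compound 2 by 3-fluoro-1H-pyrazol-1-yl in place of methoxymethyl on a saturated chain carbon bound to an aromatic carbon: 3-fluoro-1H-pyrazol-1-yl takes the place of methoxymethyl on a saturated chain carbon bound to an aromatic carbon.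

Going by the values given here, only one measured step bears on this change, a 3.0-fold lower number from compound 1 to compound 2 (0.48 log units; beyond the scatter). It is modest in size and shows that a change at this place can move the number in this assay beyond the scatter. It offers only a loose guide, however, as the entering group brings one five-membered aromatic ring with 2 hetero atoms, which neither compound 1 nor compound 2 has. The data therefore fix no direction, and no clear shift is predicted. The expected result is a 1.2-fold higher number from compound 2 to compound 3 (0.07 log units; within the scatter), an estimate that stays within the scatter. The estimated value for compound 3 is 45 mL.min-1.g-1, with an expected range from 15 mL.min-1.g-1 to 130 mL.min-1.g-1.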

Compound 3, intrinsic clearance in microsomes: 30 mL.min-1.g-1
Compound 3: middle estimate off by 1.5-fold (0.18 log units), on the high side, and the stated range covers the measured number.
By their numbers in this assay, from the lowest: compounds 3 and 2 (each within the scatter of the next); then compound 1.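

In this assay, the place on a saturated chain carbon bound to an aromatic carbon takes a ring as readily as an open chain: 3-fluoro-1H-pyrazol-1-yl in place of methoxymethyl gives a 1.3-fold lower number from compound 2 to compound 3 (0.10 log units; within the scatter), so the entering five-membered aromatic ring with 2 hetero atoms leaves the number within the scatter of the methoxymethyl compound. Against ethoxy, the same group gives a 3.8-fold lower number from compound 1 to compound 3 (0.58 log units; beyond the scatter), which shows that the low clearance seen so far is not tied to a chain carrying oxygen, and that of the three groups only ethoxy stands apart. Nothing available here accounts for these numbers.

The compounds shown leave open whether the result would hold for the same ring without its fluorine, or for an amine, a carboxylic acid or a longer chain at this place. They also leave open whether the close agreement of these two quite different groups would persist on any other core than the shared one.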